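Swapping an aromatic amine for a flexible aminoalkyl chain

A few compounds are considered here, and "the series" means these few. Any claim that something is new, unique, unknown or untested is made for them only; others in the source may bear on it.

Measured compounds:
compound 1 `Nc1ccc(Nc2c(C(=O)NCc3ccc(F)cc3)nc(Br)c3cccnc23)cc1` with 7000 nM
compound 2 `C[C@@H](CO)Nc1nc(C(=O)NCc2ccc(F)cc2)c(O)c2ncccc12` with "not determined" (no result reported)
compound 3 `C[C@H](CO)Nc1nc(C(=O)NCc2ccc(F)cc2)c(O)c2ncccc12` with "not determined" (no result reported)

Among the measured compounds shown here, compound 1 `Nc1ccc(Nc2c(C(=O)NCc3ccc(F)cc3)nc(Br)c3cccnc23)cc1` is the only compound with a number: in a functional assay on HCT-116 cells (Homo sapiens) for cytotoxicity, read by MTT assay, with a stated time of 72 h (a higher number here means a weaker inhibitor, a lower number a stronger inhibitor), compound 1 gives 7000 nM. Compound 2 `C[C@@H](CO)Nc1nc(C(=O)NCc2ccc(F)cc2)c(O)c2ncccc12` and compound 3 `C[C@H](CO)Nc1nc(C(=O)NCc2ccc(F)cc2)c(O)c2ncccc12` have no result reported in this assay, and they are distinguished only by the fact that compounds 2 and 3 differ only in the configuration as drawn, so they add nothing to compare against. For the measured compounds named here, no pair of measured compounds differs in a single place, so no measured step exists to lean on.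

Compound 4 `NCCCCCCNc1c(C(=O)NCc2ccc(F)cc2)nc(Br)c2cccnc12` has not yet been measured. It differs from compound 1 by 6-aminohexyl in place of 4-aminophenyl on a nitrogen on an aromatic ring: an aromatic amine on the nitrogen gives way to a flexible chain of the same heavy-atom count. Going by the values given here, because no measured step exists, the expected step in this assay can only be a guess: a small weakening, close to the scatter, is expected, that is a 1.4-fold higher number from compound 1 to compound 4 (0.15 log units; within the scatter). For compound 4 the estimated value is 10000 nM, with a range from 2000 nM to 50000 nM.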

Compound 4, half-maximal inhibitory concentration: > 10000 nM
Compound 4 gave a limit, no number (the forecaster's own chance of this, stated with the estimate: 15%); the middle value lies on the limit itself.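

Among the compounds shown here, compound 1 now has a partner that differs from it in one place, which the earlier compounds did not offer, and in this assay compound 4 gives > 10000 nM, a limit of the assay and not a number. Putting 6-aminohexyl in place of 4-aminophenyl on this nitrogen gives an at least 1.4-fold higher number from compound 1 to compound 4 (0.15 log units; that floor lies within the scatter), so the step has only a floor, and that floor does not clear the usual scatter. The real size of the change stays unread, and what bounds the reading is: the limit of > 10000 nM in this assay, at which 1 of the 4 values shown sits.

The compounds shown leave open what a shorter chain such as 2-aminoethyl, or a ring carrying a carboxylic acid in place of the amine, would give on this nitrogen. They also leave open whether the aromatic ring of 4-aminophenyl matters here at all.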